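The compounds below may be only part of what the source reports. "The series", "measured", "known", "first", "only" and "open" are said of these compounds alone.

Measured compounds:
compound 1 `CCN1CCN(c2cc(C)c3cc(NC(=O)c4ccc(C)cc4)ccc3n2)CC1`, 11400 nM;
compound 2 `Cc1cc(N(C)C)nc2ccc(NC(=O)c3ccc(Cl)c(Cl)c3)cc12`, > 50000 nM;
compound 3 `Cc1cc(NCCN2CCN(C)CC2)nc2ccc(NC(=O)c3ccc(Cl)c(Cl)c3)cc12`, 2690 nM.

In a functional assay on SK-BR-3 cells (Homo sapiens) for antiproliferative activity, read by MTT assay, with a stated time of 72 h (on this read-out higher numbers stand for weaker inhibition and lower numbers for stronger inhibition), compound 1 gives 11400 nM, the highest of the two numbers shown. Compound 3 gives 2690 nM. For compound 2 the result is only a limit, > 50000 nM, as noted under (the limit of > 50000 nM in this assay, at which 1 of the 3 values shown sits). Going by the values given here, the one measured step, an at least 18-fold lower number from compound 2 to compound 3 (1.26 log units; beyond the scatter), changes the amine on the core and not the amide. Compound 4 `CCN1CCN(c2cc(C)c3cc(NC(=O)c4cccc(Br)c4)ccc3n2)CC1` differs from compound 1 by 3-bromophenyl in place of 4-methylphenyl on a carbonyl carbon. Among the compounds with values here, no measured step touches this part of the molecule, so compound 4 is expected to stay close to compound 1, with a 1.0-fold lower number from compound 1 to compound 4 (0.02 log units; within the scatter), and its estimated value is 11000 nM, between 3000 nM and 40000 nM.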

Compound 4, half-maximal inhibitory concentration: 13300 nM
Compound 4: middle estimate off by 1.2-fold (0.08 log units), on the low side; the measured number falls inside the stated range.
By their numbers in this assay, from the lowest: compound 3; then compounds 1 and 4 (each within the scatter of the next). At a limit, above all of these: compound 2.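

Going by these compounds alone, compound 4 gives the first measured change on the carbonyl side of the amide, as the earlier step touched only the amine on the core. In this assay, 3-bromophenyl in place of 4-methylphenyl on this carbonyl carbon gives a 1.2-fold higher number from compound 1 to compound 4 (0.07 log units; within the scatter), so this exchange leaves the reading unchanged within the scatter while the 4-ethylpiperazine-bearing core stays the same. Nothing measured here bears on why these two groups read alike.

From the compounds shown here alone, whether a carboxylic acid or an amine on the phenyl ring would also leave the number in place remains open. So does whether a longer chain between the carbonyl and the ring would do so.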